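The source may report more compounds than this note shows. Statements on the series, on what has been measured and on what is new or still open speak of the compounds shown alone.

Compound 1 `Cc1nnc(SCc2cc(=O)c3cc(Cl)ccc3o2)s1` gives > 25000 nM in a functional assay on SW480 cells (Homo sapiens) for cytotoxicity, read by MTT assay, with a stated time of 72 h (a lower number here means a stronger inhibitor, a higher number a weaker inhibitor), which is a limit of the assay and not a number.
Compound 2 `Cc1nnc(SCc2cc(=O)c3ccccc3o2)s1` gives > 25000 nM in this assay, again a limit.

Compound 2 therefore stands at the limit of > 25000 nM in this assay, at which 2 of the 2 values shown sit. Going by the values given here, because both measured values are limits, the single measured step, a step that the two limits leave unreadable from compound 1 to compound 2, has no readable size, and compound 2 cannot be placed above or below compound 1.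

Compound 3 `Cc1ccc2oc(CSc3nnc(C)s3)cc(=O)c2c1` differs from compound 2 by methyl in place of hydrogen on an aromatic carbon. Among the compounds with values here, no measured step involves a methyl group, and the one step that exists gives no size, so nothing supports an expected shift in this assay in either direction beyond the scatter. The expected step is a step that the limit leaves unreadable from compound 2 to compound 3, that is, none that could be read. Compound 3 is estimated at 30000 nM, within a range from 10000 nM to 100000 nM, and is expected most likely to be reported only as a limit.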

Compound 3, half-maximal inhibitory concentration: > 25000 nM
Compound 3: no number, only a limit (the forecaster's own chance of this, stated with the estimate: 85%); the middle value is on the limit's open side.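

Going by these compounds alone, no step among compound 1, compound 2 and compound 3 can be read, because each value is a limit and not a number: the limit of > 25000 nM in this assay, at which 3 of the 3 values shown sit. The compounds shown leave open how far past that limit each one lies, and whether chloro, hydrogen or methyl on the aromatic carbon makes any difference in this assay.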